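From thiophen-3-yl to 4-fluorophenyl on the shared core

The source may hold more compounds than are shown below. What is called first, only, known or untested is meant among the compounds shown, and "the series" means these compounds.

Compound 1 `COc1cc(C(=O)c2sc(-c3ccc(-c4ccccc4)cc3)cc2N)cc(OC)c1OC`: > 10000 nM (a limit of the assay)
Compound 2 `COc1cc(C(=O)c2sc(-c3ccc(Cl)cc3)cc2N)cc(OC)c1OC`: 90 nM
Compound 3 `COc1cc(C(=O)c2sc(-c3ccsc3)cc2N)cc(OC)c1OC`: 3.7 nM
Compound 4 `COc1cc(C(=O)c2sc(-c3ccc(F)cc3)cc2N)cc(OC)c1OC`: not yet measured

In a functional assay on FM3A cells (Mus musculus) for antiproliferative activity (on this read-out higher numbers stand for weaker inhibition and lower numbers for stronger inhibition), compound 3 gives 3.7 nM, the lower of the two exact numbers, and compound 2 is its nearest neighbour. Compound 4 carries a single change, 4-fluorophenyl in place of thiophen-3-yl on an aromatic carbon. The closest guide is compound 2, which has 4-chlorophenyl at that place. The step of a 24-fold lower number from compound 2 to compound 3 (1.39 log units; beyond the scatter) was large, and so was the step of an at least 110-fold lower number from compound 1 to compound 2 (2.04 log units; beyond the scatter), so this place clearly matters. Returning to a 4-substituted phenyl should therefore largely reverse the first of these gains, and a large step toward weaker inhibition is expected: a 12-fold higher number from compound 3 to compound 4 (1.09 log units; beyond the scatter). For compound 4 the estimated value is 45 nM, with an expected range of 10 nM to 200 nM.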

Compound 4, half-maximal inhibitory concentration: 16 nM
Compound 4: middle estimate off by 2.8-fold (0.45 log units), on the high side, and the stated range covers the measured number.
By their numbers in this assay, from the lowest: compound 3; then compound 4; then compound 2. At a limit, above all of these: compound 1.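

Swapping thiophen-3-yl for a phenyl ring need not cost much at this place in this assay: the change gives a 4.3-fold higher number from compound 3 to compound 4 (0.64 log units; beyond the scatter). The group on that phenyl ring also matters, since fluoro in place of chloro gives a 5.6-fold lower number from compound 2 to compound 4 (0.75 log units; beyond the scatter). Compound 1 stands at a limit of the assay, so this step is only a bound: an at least 620-fold lower number from compound 1 to compound 4 (2.79 log units; beyond the scatter).

Going by these compounds, how 4-methoxyphenyl, 4-aminophenyl or a plain phenyl ring would compare at this place remains open. So does whether a pyridine ring would match thiophen-3-yl.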